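Demethylation of a benzofuran bis-amidine core, second time round

A few compounds are considered here, and "the series" means these few. Any claim that something is new, unique, unknown or untested is made for them only; others in the source may bear on it.

Compound 1 `COc1cc(C(=N)NC(C)C)ccc1-c1cc2cc(C(=N)NC(C)C)ccc2o1` and compound 2 `CC(C)NC(=N)c1ccc(-c2cc3cc(C(=N)NC(C)C)ccc3o2)c(O)c1` share one core and differ by hydrogen in place of methyl on an oxygen on an aromatic ring. In an ADME assay on L6 cells (Rattus norvegicus) for cytotoxicity (a lower number here means a stronger inhibitor, a higher number a weaker inhibitor), compound 1 gives 98100 nM. Compound 2 reaches only a limit of the assay in this assay, > 183000 nM, which is the limit (the limit of > 183000 nM in this assay, at which 1 of the 3 values shown sits). The change therefore made an at least 1.8-fold higher number from compound 1 to compound 2 (0.27 log units; that floor lies within the scatter).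

Compound 3 `COc1ccc(C2=NCCN2)cc1-c1cc2ccc(C3=NCCN3)cc2o1` carries a different core; how its core differs from that of compound 1 is not broken down here. In this assay, among the compounds with values here, compound 3 gives 11100 nM, the lowest of the two numbers so far.

Compound 4 `Oc1ccc(C2=NCCN2)cc1-c1cc2ccc(C3=NCCN3)cc2o1` is not yet measured. It differs from compound 3 by hydrogen in place of methyl on an oxygen on an aromatic ring, the same change as that from compound 1 to compound 2, at the same place.

Resting on the step that this change made from compound 1 to compound 2 an at least 1.8-fold higher number from compound 1 to compound 2 (0.27 log units; that floor lies within the scatter), compound 4 is expected to move by a 2.0-fold higher number from compound 3 to compound 4 (0.30 log units; within the scatter) in this assay. Compound 4 is therefore estimated at 22000 nM, with a range from 9000 nM to 60000 nM.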

Compound 4, half-maximal inhibitory concentration: > 189000 nM
Compound 4 gave a limit, no number; the forecaster's own chance of this, stated with the estimate: 5%; middle value at least 8.5-fold (0.93 log units) from the limit.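

On the second core, the change from methoxy to hydroxy made an at least 17-fold higher number from compound 3 to compound 4 (1.23 log units; beyond the scatter); that figure is a floor set by a limit of the assay, not a measured step. Set beside the earlier step in this assay, the transfer of this change between cores can be read only as far as two floors allow: the same change on two cores in this assay, an at least 1.8-fold higher number (0.27 log units; that floor lies within the scatter) from compound 1 to compound 2 and an at least 17-fold higher number (1.23 log units; beyond the scatter) from compound 3 to compound 4; the limit leaves it open whether they differ

The two pairs show that on both cores the hydroxy compound ends at a limit of the assay, but they do not show that the change has the same size on both cores, or that it is larger on one of them.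

The compounds shown leave open where compound 2 and compound 4 would lie if they gave numbers, as each has only a limit. They also leave open how this assay would respond on either core to an ethoxy group or an amine in place of the methoxy.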